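A few compounds are considered here, and "the series" means these few. Any claim that something is new, unique, unknown or untested is made for them only; others in the source may bear on it.

Among the measured compounds shown here, compound 2 `CC(=O)N1CCC(n2cc(-c3cnc(N)c4oc(-c5csc6ccccc56)cc34)cn2)CC1` gives 0.68 in an ADME assay on microsomes from liver (Homo sapiens) for metabolic stability (a lower number here means that the liver removes a smaller share, a higher number that the liver removes a larger share of the compound in one pass), the higher of the two numbers known; compound 1 `CC(=O)N1CCC(n2cc(-c3cnc(N)c4oc(-c5cn(C)c6cnccc56)cc34)cn2)CC1` gives 0.64, and the step a number 0.040 higher from compound 1 to compound 2 (within the scatter) lies within the scatter. Compound 3 `CC(=O)N1CCC(n2cc(-c3cnc(N)c4oc(-c5csc6cnccc56)cc34)cn2)CC1` differs from compound 2 by a group of 9 heavy atoms (7 carbon, 1 nitrogen, 1 sulfur; one five-membered aromatic ring with 1 hetero atom, one six-membered aromatic ring with 1 hetero atom) in place of a group of 9 heavy atoms (8 carbon, 1 sulfur; one five-membered aromatic ring with 1 hetero atom, one six-membered aromatic ring of carbon only), on an aromatic carbon. For the measured compounds named here, the one measured step, swapping one fused bicyclic group for another, did not move this assay beyond the scatter, so for compound 3 a change of about a number 0.050 lower from compound 2 to compound 3 (within the scatter) is expected, with no clear direction. Compound 3 is therefore estimated at 0.63, most likely between 0.49 and 0.77.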

Compound 3, hepatic extraction ratio: 0.68
For compound 3 the middle estimate is 0.050 below the measured one; measured number inside the range.
By their numbers in this assay, from the lowest: compounds 1, 2 and 3 (each within the scatter of the next).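

In this assay, putting a nitrogen into the six-membered ring of the 1-benzothiophen-3-yl group gives no change at the digits printed from compound 2 to compound 3 (within the scatter) and thus shows that this ring can carry a hetero atom without a step beyond the scatter. The further step, a number 0.040 higher from compound 1 to compound 3 (within the scatter), places all three fused groups tried on this aromatic carbon next to the ring oxygen within the scatter of one another. Nothing at hand accounts for this flatness. Still open, as far as these compounds go, is whether a single phenyl ring here, or an amine or a carboxylic acid on the fused group, would move the number beyond the scatter.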